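The compounds below may be only part of what the source reports. "The series", "measured", "known", "first", "only" and "open" are said of these compounds alone.

In a functional assay on HL-60 cells (Homo sapiens) for cytotoxicity, read by MTT assay, with a stated time of 24 h (a higher number here means a weaker inhibitor, a lower number a stronger inhibitor), three compounds that share one core and differ in the chain attached through an oxygen have been measured. Compound 1 `BrCCCCCCOc1c(Br)cc(Br)cc1Oc1ccc(Br)cc1Br` gives 37.8 ug/mL, compound 2 `COc1ccccc1N1CCN(CCCCCOc2c(Br)cc(Br)cc2Oc2ccc(Br)cc2Br)CC1` gives 32.2 ug/mL, and compound 3 `Cc1ccc(S(=O)(=O)n2nc(N3CCN(CCCCCOc4c(Br)cc(Br)cc4Oc4ccc(Br)cc4Br)CC3)c3cc([N+](=O)[O-])ccc32)cc1` gives 52.5 ug/mL. These three numbers all lie within the usual scatter of one another, so compound 1 cannot be ranked against either of the other two.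

Compound 4 `BrCCOc1c(Br)cc(Br)cc1Oc1ccc(Br)cc1Br` has not yet been measured. It keeps the core of compound 1, and only the chain differs: bromo in place of 4-bromobutyl on a saturated chain carbon, two bonds along the chain from an oxygen on an aromatic ring. Put another way, 6-bromohexyl becomes 2-bromoethyl.

Going by the values given here, no two measured compounds differ in just one place, so the data give no direct size for such a change. Still, compound 3 at 52.5 ug/mL carries a far larger group on its chain than compound 1 at 37.8 ug/mL, and the two remain within the scatter. No step beyond the scatter, in either direction, is therefore expected in this assay. The estimated step is a 1.1-fold higher number from compound 1 to compound 4 (0.02 log units; within the scatter). Compound 4 is expected at 40 ug/mL, with an estimated range of 18 ug/mL to 85 ug/mL.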

Compound 4, half-maximal inhibitory concentration: 26.2 ug/mL
Compound 4: the middle estimate sits 1.5-fold (0.18 log units) above what was measured, and the stated range covers the measured number.
By their numbers in this assay, from the lowest: compounds 4, 2, 1 and 3 (each within the scatter of the next).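

Read directly for the first time, a change at this position gives, in this assay, a 1.4-fold lower number from compound 1 to compound 4 (0.16 log units; within the scatter), so 6-bromohexyl and 2-bromoethyl cannot be told apart in this assay. A single comparison therefore shows that the four chain carbons that leave with the 4-bromobutyl group can go without a step beyond the scatter, in this core and with a bromo as the group that enters. The earlier compounds could only hint at this, since each of them differs from the others in more than one place, and nothing available explains the result or says how the chain acts on these cells.

Whether the bromo itself counts remains open, since every chain here either ends in a bromo or carries a larger nitrogen-containing group, and a plain ethyl chain, a chain ending in a primary amine and one ending in a carboxylic acid lie outside the compounds shown. These four compounds also leave open whether any group at this position can produce a step beyond the scatter.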